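The source may report more compounds than this note shows. Statements on the series, on what has been measured and on what is new or still open speak of the compounds shown alone.

Measured so far:
- Compound 2, `N/N=C\c1cc(=O)oc2cc(OCc3ccccc3)cc(OCc3ccccc3)c12`: > 2000000 nM
- Compound 1, `O=c1cc(/C=N\c2ccccc2O)c2ccc(OCc3ccccc3)cc2o1`: "not active" (no number reported)
- Compound 3, `N/N=C\c1cc(=O)oc2cc(OCc3ccccc3)ccc12`: "not active" (no number reported)

Of the compounds shown here, three have been tested in a functional assay, read by spectrophotometry, with a stated time of 1 h; a higher number here means a weaker inhibitor, a lower number a stronger inhibitor. Compound 1 is recorded as "not active" (no number reported). Compound 3 is likewise recorded as "not active" (no number reported). Compound 2 yields only a limit of the assay, > 2000000 nM. Compound 2 therefore sits at the limit of > 2000000 nM in this assay, at which 1 of the 3 values shown sits, and none of the three measured compounds has a single number attached to it. For the measured compounds named here, with no pair of measured compounds differing in just one place, no measured step is available to lean on.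

The next compound, compound 4, `O=c1cc(/C=N\c2ccc(O)cc2)c2c(OCc3ccccc3)cc(OCc3ccccc3)cc2o1`, differs from compound 2 in one place: 4-hydroxyphenyl in place of amino on a double-bonded nitrogen. Going by the values given here, compound 1, whose structure stands above and which also carries an aromatic ring on the double-bonded nitrogen, shows no activity, and nothing among the measured compounds points to a gain in this assay from such a change. The step from compound 2 is therefore expected to be a number no higher from compound 2 to compound 4 (the limit leaves the size open), that is, no shift beyond the scatter. Compound 4 is accordingly expected to come out at about 2000000 nM, within a range from 200000 nM to 20000000 nM, and most likely to be reported again only as a limit rather than a number.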

Compound 4, half-maximal inhibitory concentration: 107000 nM
Compound 4: the middle estimate sits 19-fold (1.27 log units) above what was measured; measured number below the stated range.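

In this assay, the place on the double-bonded nitrogen proves able to change the result: 4-hydroxyphenyl in place of amino gives an at least 18-fold lower number from compound 2 to compound 4 (1.27 log units; beyond the scatter). For the compounds shown here, compound 4 is also the first compound here with a single number rather than a limit or a "not active" record. A lower number means a stronger inhibitor, and this larger group on the nitrogen marks a real gain over amino on the same core. The true size of the step stays open on one side because compound 2 gives only a limit: the limit of > 2000000 nM in this assay, at which 1 of the 4 values shown sits.

The compounds shown do not separate the contribution of the aromatic ring from that of its hydroxyl, so a plain phenyl, a 4-methoxyphenyl or a saturated cyclohexyl on the same nitrogen would be the informative comparisons with compound 4. They also leave open whether a different group at the far end of the ring, such as an amine or a carboxylic acid, would push the number lower still, and whether the gain holds on a core with a different set of benzyloxy groups.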